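The source may report more compounds than this note shows. Statements on the series, on what has been measured and on what is new or still open speak of the compounds shown alone.

Compound 2 `COc1cccc(OC2=C(Cl)C(=O)c3c(OC(C)=O)ccc(OC(C)=O)c3C2=O)c1` is the weakest of the three measured compounds in a functional assay on NCI cells (Homo sapiens) for inhibition; on this read-out lower numbers stand for stronger inhibition and higher numbers for weaker inhibition. Against the other two it stands alone: in this assay compound 2 gives 1000 nM, while compound 1 `COc1cccc(OC2=C(Oc3cccc(OC)c3)C(=O)c3c(OC)ccc(OC)c3C2=O)c1` gives 100 nM and compound 3 `O=C1C=CC(=O)c2c(O)c(Oc3ccccc3)c(Oc3ccccc3)c(O)c21` gives 100 nM, each of them a gap beyond the scatter from compound 2, and the two lower numbers lie within the scatter of each other.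

Compound 4 `COc1cc(OC)cc(OC2=C(Cl)C(=O)c3c(OC(C)=O)ccc(OC(C)=O)c3C2=O)c1` has not been measured. It differs from compound 2 in one place: methoxy in place of hydrogen on an aromatic carbon. In other words, the 3-methoxyphenyl of compound 2 becomes 3,5-dimethoxyphenyl, with the new group entering on an aromatic carbon of a six-membered aromatic ring of carbon only, meta to a large group and meta to a methoxy group.

Going by the values given here, no measured pair shows this change, so nothing here tells which way it moves the number. The expectation is therefore a step from compound 2 to compound 4 of no change at the digits printed from compound 2 to compound 4 (within the scatter), with no shift beyond the scatter expected. Compound 4 is estimated to give 1000 nM in this assay, between 300 nM and 3000 nM.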

Compound 4, half-maximal inhibitory concentration: 1000 nM
Estimate against measurement, compound 4: no gap at the digits printed; low and high end bracket the measured number.
By their numbers in this assay, from the lowest: compounds 1 and 3 (each within the scatter of the next); then compounds 2 and 4 (each within the scatter of the next).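

In this assay, placing methoxy on this aromatic carbon, meta to a large group and meta to a methoxy group, gives no change at the digits printed from compound 2 to compound 4 (within the scatter). Going by these compounds alone, this is the first comparison in the set between compounds that differ in one place, and it shows that going from 3-methoxyphenyl to 3,5-dimethoxyphenyl leaves the number unmoved beyond the scatter in this chlorinated diacetate series. No measurement at hand speaks to why the number holds at this position.

Going by these compounds, it remains open whether an amine, a carboxylic acid, fluorine or a longer chain such as butoxy would leave the number equally unmoved on this carbon. On these data alone, it also remains open whether the same methoxy step would read alike on the aryl rings of compound 1 or on the phenyl rings of compound 3.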